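Swapping a Ring-Bearing Side Chain for an Amide

The compounds below may be only part of what the source reports. "The series", "measured", "known", "first", "only" and "open" are said of these compounds alone.

Compound 1 `Cn1ncc(Cl)c1-c1cc(C(=O)N[C@H]2CNCC[C@@H]2c2ccc(C(F)(F)F)cc2)oc1Cl` gives 1050 nM in a functional assay on HCT-116 cells (Homo sapiens) for antiproliferative activity, read by sulforhodamine B assay, with a stated time of 72 h; a higher number here means a weaker inhibitor, a lower number a stronger inhibitor. Compound 2 `Cn1ncc(Cl)c1-c1cc(C(=O)N[C@@H]2CN[C@H](CCN3CCCC3)C[C@H]2c2ccc(Cl)c(Cl)c2)oc1Cl` gives 1940 nM in this assay, the higher of the two numbers, with compound 1 the nearer one within the usual scatter. Compound 3 `Cn1ncc(Cl)c1-c1cc(C(=O)N[C@@H]2CN[C@H](CC(=O)NCCO)C[C@H]2c2ccc(Cl)c(Cl)c2)oc1Cl` differs from compound 2 in one place: (2-hydroxyethyl)carbamoyl in place of (pyrrolidin-1-yl)methyl on a saturated chain carbon bound to a saturated ring carbon. Among the compounds with values here, with no comparable step among the measured compounds, the step from compound 2 to compound 3 is expected to stay within the scatter, leaning toward a slightly higher number, as a 1.4-fold higher number from compound 2 to compound 3 (0.16 log units; within the scatter). Compound 3 is therefore estimated at 2800 nM, plausibly between 900 nM and 9000 nM.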

Compound 3, half-maximal inhibitory concentration: 670 nM
For compound 3 the middle estimate is 4.2-fold (0.62 log units) above the measured one; measured number below the stated range.
By their numbers in this assay, from the lowest: compounds 3, 1 and 2 (each within the scatter of the next, the first and the last beyond it).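

On a saturated chain carbon bound to a saturated ring carbon, this assay responds to the kind of group present: (2-hydroxyethyl)carbamoyl in place of (pyrrolidin-1-yl)methyl gives a 2.9-fold lower number from compound 2 to compound 3 (0.46 log units; beyond the scatter), a modest step. The pyrrolidine ring is therefore not needed at this position to keep the number this low. No measurement at hand explains the step. The change removes the ring and adds a carbonyl and hydrogen-bond donors together, so the compounds shown leave open which of these matters. A carboxylic acid or a primary amine on the same chain could help separate them.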